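Methyl to Methoxy on the Aromatic Ring

The compounds below may be only part of what the source reports. "The series", "measured", "known", "first", "only" and "open" are said of these compounds alone.

Of the compounds shown here, two built on one shared core have so far been measured in a functional assay on MCF7 cells (Homo sapiens) for inhibition, read by MTT assay, with a stated time of 24 h; a higher number here means a weaker inhibitor, a lower number a stronger inhibitor. Compound 1 `FC(F)(F)c1ccc(/C=C/[C@@H]2CCCCN2)cc1` carries a trifluoromethyl on the aromatic ring, and in this assay compound 1 gives 1.25 ug/mL. Compound 2 `Cc1ccc(/C=C/[C@@H]2CCCCN2)cc1` carries a methyl instead, and in this assay compound 2 gives 5.35 ug/mL. Among the compounds with values here, the only recorded step is a 4.3-fold higher number from compound 1 to compound 2 (0.63 log units; beyond the scatter), which leaves compound 2 with the higher of the two numbers. Compound 3 `COc1ccc(/C=C/[C@@H]2CCCCN2)cc1` differs from compound 2 in a single place: methoxy in place of methyl on an aromatic carbon. Within the data shown here, no measured step involves a methoxy, and the exchange of trifluoromethyl for methyl bears only loosely on this change. For compound 3 the expected step in this assay is therefore a 1.1-fold higher number from compound 2 to compound 3 (0.05 log units; within the scatter), which is not beyond the scatter. Compound 3 is estimated at 6 ug/mL in this assay, with a range from 2.5 ug/mL to 14 ug/mL.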

Compound 3, half-maximal inhibitory concentration: 3.57 ug/mL
The estimate for compound 3 lay 1.7-fold (0.23 log units) above the measured number, within the range that was stated.
By their numbers in this assay, from the lowest: compound 1; then compounds 3 and 2 (each within the scatter of the next).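

The position now has a third group, and the methoxy introduces the first hydrogen-bond acceptor at this aromatic carbon, yet a 1.5-fold lower number from compound 2 to compound 3 (0.18 log units; within the scatter) in this assay. Methyl and methoxy therefore cannot be told apart here, while trifluoromethyl stands apart from both: besides the earlier gap to the methyl, there is a 2.9-fold higher number from compound 1 to compound 3 (0.46 log units; beyond the scatter), which makes compound 1 the strongest inhibitor of the three. Nothing at hand explains why trifluoromethyl differs from the other two groups.

The compounds shown leave open what a chlorine, a nitrile or an amine on this carbon would give in this assay. They also leave open whether any of these groups would match trifluoromethyl or stay with methyl and methoxy.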